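Replacing a fluorinated ring with a chlorophenylpropyl chain

This account rests on a few compounds, and the source may have more. Where it says the series, first, only, none or still open, it means among the compounds named here.

Going by the values given here, compound 2, `Nc1scc(CN2CCN(c3c(F)cc(F)cc3F)CC2)c1C(=O)c1ccc(Cl)cc1`, is one of two compounds measured in a functional assay on CHO cells with adenosine receptor A1 (Homo sapiens) as the target, read by cAMP accumulation and immunoassay, with a stated time of 6 min, tested at 0.1 uM; on this read-out lower numbers stand for a stronger effect and higher numbers for a weaker effect at the one concentration tested. In this assay compound 2 gives -3.9%, and its closest neighbour, compound 1, `Nc1scc(CN2CCN(c3cccc(F)c3F)CC2)c1C(=O)c1ccc(Cl)cc1`, gives -5.2%. Among the compounds with values here, the only step measured so far, a number 1.3 percentage points higher from compound 1 to compound 2 (within the scatter), shows that changing the fluorine pattern on the aromatic ring attached to the ring amine nitrogen leaves the read-out essentially unchanged.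

Compound 3, `Nc1scc(CN2CCN(CCCc3ccc(Cl)cc3)CC2)c1C(=O)c1ccc(Cl)cc1`, has not been measured. It differs from compound 2 at the same ring nitrogen: 3-(4-chlorophenyl)propyl in place of 2,4,6-trifluorophenyl on an amine nitrogen in a ring. This is a different kind of change from the one already measured, since a whole aromatic ring is exchanged for a three-carbon chain ending in a chlorophenyl group, so the step from compound 1 to compound 2 bears on it only loosely. With both measured compounds sitting close to zero, the expected step of a number 5.9 percentage points higher from compound 2 to compound 3 (within the scatter) is no change beyond the scatter, though the uncertainty is larger than for the measured step. Compound 3 is therefore estimated to give 2% in this assay, expected to fall between -15% and 20%.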

Compound 3, a percentage reported as activity, at one concentration (the size of the read-out at that concentration, not a potency): -3%
Compound 3: the middle estimate sits 5 percentage points above what was measured; the range from low to high includes it.
By their numbers in this assay, from the lowest: compounds 1, 2 and 3 (each within the scatter of the next).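

Compound 1 and compound 2 varied only the fluorine pattern on a phenyl ring attached to the ring nitrogen, whereas compound 3 carries a 3-(4-chlorophenyl)propyl group at that nitrogen; in this assay, the result is a number 0.9 percentage points higher from compound 2 to compound 3 (within the scatter) and a number 2.2 percentage points higher from compound 1 to compound 3 (within the scatter). At this one concentration, the read-out therefore does not separate a fluorinated phenyl ring on the nitrogen from a chlorophenyl ring carried at the end of a propyl chain, so this larger change at the position registers no more than the fluorine shift did. Nothing measured here explains this outcome.

All the groups shown at this nitrogen end in a halogen-bearing phenyl ring, so it remains open whether a group without that ring, such as a small methyl, or a propyl chain ending in an amine or a carboxylic acid, would separate from these three compounds. The role of the chain itself is also unsettled, since a shorter ethyl or longer butyl link to the 4-chlorophenyl ring would be needed to test it.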